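This account rests on a few compounds, and the source may have more. Where it says the series, first, only, none or still open, it means among the compounds named here.

Compound 1 `CC1CCN(C2CCN(S(=O)(=O)c3cccnc3)CC2)CC1`: > 10000 nM, a limit.
Compound 2 `CC1CCN(C2CCN(S(=O)(=O)c3cccc(-c4ccc5ccccc5c4)c3)CC2)CC1`: > 5000 nM, a limit.
Compound 3 `CC1CCN(C2CCN(S(=O)(=O)c3cc(F)c(Br)c(F)c3)CC2)CC1`: > 5000 nM, a limit.

All three readings come from an ADME assay on HCT-116 cells (Homo sapiens) for cytotoxicity, read by CellTiter-Glo, with a stated time of 72 h (on this read-out higher numbers stand for weaker inhibition and lower numbers for stronger inhibition), and each is a limit rather than a number. The position of compound 2 is the limit of > 5000 nM in this assay, at which 2 of the 3 values shown sit. The series therefore offers no measured number and no ranking among its three members.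

Compound 4 `Cc1cc(C)cc(-c2cccc(S(=O)(=O)N3CCC(N4CCC(C)CC4)CC3)c2)c1` keeps the shared core of compound 2 and changes one group: 3,5-dimethylphenyl in place of naphthalen-2-yl on an aromatic carbon. In words, 3,5-dimethylphenyl stands in place of naphthalen-2-yl on an aromatic carbon, meta to a large group.

Among the measured compounds shown here, no measured step shows what such an exchange does in this assay, so the expectation rests on the limits alone. The main reference is compound 2, with its limit of > 5000 nM. No change beyond the usual scatter is expected in either direction, and the estimated step is a step that the limit leaves unreadable from compound 2 to compound 4. The most likely outcome is another limit rather than a number. The estimated value for compound 4 is 7000 nM, with an expected range of 3000 nM to 15000 nM.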

Compound 4, half-maximal inhibitory concentration: > 5000 nM
Compound 4 was reported as a limit; the forecaster's own chance of this, stated with the estimate: 80%; the middle value lies beyond the limit too.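

Compound 2 and compound 4 both stand as limits in this assay, and no step can be read between them for 3,5-dimethylphenyl in place of naphthalen-2-yl. The compounds shown leave open whether any member of the series gives a measurable half-maximal inhibitory concentration in this assay, and how far a group exchange would move it.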